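Removing the Chloro Group from the Aryl Imine

This account rests on a few compounds, and the source may have more. Where it says the series, first, only, none or still open, it means among the compounds named here.

The three measured compounds share one core and differ only in the aryl group on the imine nitrogen. Compound 1 `COc1ccc(/C=C2\S/C(=N\c3ccccc3)N(C)C2=O)cc1` carries a plain phenyl group. In a functional assay on HCT-116 cells (Homo sapiens) for antiproliferative activity, read by MTT assay, with a stated time of 72 h (on this read-out lower numbers stand for stronger inhibition and higher numbers for weaker inhibition), compound 1 gives only a limit, > 100000 nM, and no number. Compound 2 `COc1ccc(/C=C2\S/C(=N\c3ccc(Cl)cc3)N(C)C2=O)cc1` carries a chloro group on that ring and gives 10400 nM in this assay. Compound 3 `COc1ccc(/C=C2\S/C(=N\c3ccc(C)c(Cl)c3)N(C)C2=O)cc1` carries a 3-chloro-4-methylphenyl group and gives 14100 nM in this assay; this is the higher of the two numbers recorded, and the step to its nearest neighbour, a 1.4-fold higher number from compound 2 to compound 3 (0.13 log units; within the scatter), lies within the scatter.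

Compound 4 `COc1ccc(/C=C2\S/C(=N\c3ccc(C)cc3)N(C)C2=O)cc1` differs from compound 3 in one place: hydrogen in place of chloro on an aromatic carbon. Going by the values given here, two measured steps bear on this change. Adding chloro to the phenyl group gave an at least 9.6-fold lower number from compound 1 to compound 2 (0.98 log units; beyond the scatter), and the move to the 3-chloro-4-methylphenyl group gave an at least 7.0-fold lower number from compound 1 to compound 3 (0.85 log units; beyond the scatter). Here chloro leaves while the methyl group stays, so the change runs back toward the unsubstituted ring of compound 1, which sits at a limit (the limit of > 100000 nM in this assay, at which 1 of the 3 values shown sits). A higher number is therefore expected for compound 4, estimated as a 2.8-fold higher number from compound 3 to compound 4 (0.45 log units; beyond the scatter), though the remaining methyl group leaves the size uncertain. Compound 4 is expected at 40000 nM, within 12000 nM to 150000 nM.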

Compound 4, half-maximal inhibitory concentration: > 100000 nM
Compound 4: a limit, no number; the forecaster's own chance of this, stated with the estimate: 35%; at least 2.5-fold (0.39 log units) between middle value and limit.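

Compound 4 shows that the methyl group alone does not give a measurable number on this ring. In this assay, hydrogen in place of chloro gives an at least 7.0-fold higher number from compound 3 to compound 4 (0.85 log units; beyond the scatter), and methyl in place of chloro gives an at least 9.6-fold higher number from compound 2 to compound 4 (0.98 log units; beyond the scatter), so among the four compounds shown only the two rings that carry chloro, in compound 2 and compound 3, give numbers rather than a limit. The gain from chloro now appears on the 4-methylphenyl ring as well as on the plain phenyl ring, and compound 1 and compound 4 both stand at a limit, which leaves the step between them unreadable and the effect of the methyl group unseen: the limit of > 100000 nM in this assay, at which 2 of the 4 values shown sit.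

From the compounds shown here alone, the true size of the gain from chloro stays open on both rings, and so does any difference between them: the same change on two cores in this assay, an at least 9.6-fold lower number (0.98 log units; beyond the scatter) from compound 1 to compound 2 and an at least 7.0-fold lower number (0.85 log units; beyond the scatter) from compound 4 to compound 3; the limit leaves it open whether they differ Also open is whether bromo, a methoxy group or an amine on that aromatic carbon, ortho to the methyl group, would give a measurable number as chloro does.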